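The source may hold more compounds than are shown below. What is called first, only, known or untested is meant among the compounds shown, and "the series" means these compounds.

Of the compounds shown here, three built on one shared core have been tested in a functional assay on the whole organism for inhibition, with Rattus norvegicus as the target, at a dose of 25 mg/kg by the intraperitoneal route; a higher number here means more inhibition at the dose given (going by the name of the read-out), a lower number less inhibition. Compound 1 `CN(C)c1ncnc2c1ncn2Cc1ccc([N+](=O)[O-])cc1` gives 0% in this assay. Compound 2 `CC(=O)Nc1ccc(Cn2cnc3c(N(C)C)ncnc32)cc1` gives 0% in this assay. Within the data shown here, the one measured step, no change at the digits printed from compound 1 to compound 2 (within the scatter), goes with acetamido in place of nitro on an aromatic carbon. Compound 3 `CN(C)c1ncnc2c1ncn2CC1CCCCC1` gives 0% in this assay, level with compound 1 and compound 2 at the digits shown; it sits within the scatter of both, so no order among the three can be read, and none of them shows inhibition at the dose given.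

Compound 4 `CCCCCn1cnc2c(N(C)C)ncnc21` has not yet been measured. It differs from compound 3 in one place: butyl in place of cyclohexyl on a saturated chain carbon bound to an aromatic nitrogen. Among the measured compounds shown here, no measured step swaps one saturated group for another, so the only guide is that the shared core, carrying three different groups, gave no inhibition in every case. For the measured compounds named here, the expected step of no change at the digits printed from compound 3 to compound 4 (within the scatter) is therefore none beyond the scatter, because compound 3 gives 0% and the single measured step of no change at the digits printed from compound 1 to compound 2 (within the scatter) moved nothing beyond the scatter either. Compound 4 is estimated at 0% in this assay, with a range from 0% to 10%.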

Compound 4, a percentage reported as inhibition, in the whole organism at one dose (the size of the read-out at that dose, not a potency): 0%
Compound 4: middle estimate and measured number agree at the digits printed, and the stated range covers the measured number.
By their numbers in this assay, from the lowest: compounds 1, 2, 3 and 4 (each within the scatter of the next).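

In this assay, butyl in place of cyclohexyl on a saturated chain carbon bound to an aromatic nitrogen goes with no change at the digits printed from compound 3 to compound 4 (within the scatter). Among these compounds, the earlier measured step changed a group on an aromatic carbon, so this is the first look at a swap of one saturated group for another at this place, and it shows that trading the six-membered ring for an open chain brings out no inhibition at the dose given. No outside measurement bears on this result.

With every compound shown giving the same reading at a single dose, the numbers cannot rank these groups or show whether any group at this place can move the read-out at all. Still open, on these data alone, is what would happen with a longer chain such as decyl, with a chain ending in an amine or a carboxylic acid, or with a different group in place of the dimethylamino group on the shared core.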